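Homologating the hydroxyacyl group on a thiophene amide series

The source may hold more compounds than are shown below. What is called first, only, known or untested is meant among the compounds shown, and "the series" means these compounds.

Compound 3 `CC1(C)Cc2c(sc(NC(=O)[C@@H](O)C(C)(C)C)c2C(N)=O)C(C)(C)O1` gives the lowest number of the three measured compounds in an assay on cells for positive allosteric modulation of Cystic fibrosis transmembrane conductance regulator variant F508del (Homo sapiens), with stated times of 10 min and 7 s, in the presence of a further agent that is not named here (on this read-out higher numbers stand for an effect only at larger amounts of compound and lower numbers for an effect already at smaller amounts), with a value of 2.7 nM. Compound 2 `CC1(C)Cc2c(sc(NC(=O)C(C)(C)O)c2C(N)=O)C(C)(C)O1` gives 16 nM in this assay, and compound 1 `CC1(C)Cc2c(sc(NC(=O)C3CCNC3=O)c2C(N)=O)C(C)(C)O1` gives 101 nM. The steps of a 6.3-fold lower number from compound 1 to compound 2 (0.80 log units; beyond the scatter), a 37-fold lower number from compound 1 to compound 3 (1.57 log units; beyond the scatter) and a 5.9-fold lower number from compound 2 to compound 3 (0.77 log units; beyond the scatter) show that the group on the carbonyl carbon governs the read-out strongly. Compound 4 `CC(C)(C)CC(O)C(=O)Nc1sc2c(c1C(N)=O)CC(C)(C)OC2(C)C` differs from compound 3 in that a group of 7 heavy atoms (6 carbon, 1 oxygen; no ring) in place of a group of 6 heavy atoms (5 carbon, 1 oxygen; no ring), on a carbonyl carbon: a group of 7 heavy atoms in place of a group of 6 heavy atoms, on a carbonyl carbon whose other neighbour is the amide-type nitrogen. For the measured compounds named here, no measured step matches this change directly; the step from compound 2 to compound 3 shows that enlarging the group lowered the number, but here the hydroxyl is displaced along the chain and the stereocentre is left undefined. A modest rise in the number, a 3.0-fold higher number from compound 3 to compound 4 (0.47 log units; beyond the scatter), is therefore expected. The estimate for compound 4 in this assay is 8 nM, within a range from 2 nM to 35 nM.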

Compound 4, half-maximal effective concentration: 0.54 nM
Compound 4: the middle estimate sits 15-fold (1.17 log units) above what was measured, outside the stated range (below it).
By their numbers in this assay, from the lowest: compound 4; then compound 3; then compound 2; then compound 1.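

In this assay, the group on the carbonyl carbon had not reached its lowest number at 1-hydroxy-2,2-dimethylpropyl: the group of 7 heavy atoms, which has no defined stereocentre, gives a 5.0-fold lower number from compound 3 to compound 4 (0.70 log units; beyond the scatter). The open-chain groups now give lower numbers as their heavy-atom count rises, with a 30-fold lower number from compound 2 to compound 4 (1.47 log units; beyond the scatter) extending the trend, while compound 1 goes against a link to size alone, since its ring-bearing group has as many heavy atoms as that of compound 3 and the step is a 190-fold lower number from compound 1 to compound 4 (2.27 log units; beyond the scatter). Nothing available here accounts for these differences.

Going by these compounds, whether a longer chain would lower the number further remains open, as does the effect of an amine in place of the hydroxyl. The compounds shown also leave open how each single stereoisomer of compound 4 would behave.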